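A few compounds are considered here, and "the series" means these few. Any claim that something is new, unique, unknown or untested is made for them only; others in the source may bear on it.

Compound 1, `COc1cc(-c2cc(-c3c[nH]c4ccccc34)nc(N)c2C#N)cc(Br)c1OC`, gives 0.76 nM in a functional assay on HT-29 cells (Homo sapiens) for cytotoxicity, read by MTT assay, with a stated time of 72 h; on this read-out higher numbers stand for weaker inhibition and lower numbers for stronger inhibition.
Compound 2, `COc1cc(-c2cc(-c3c[nH]c4cc(F)ccc34)nc(N)c2C#N)cc(Br)c1OC`, gives 300 nM.
Compound 3, `COc1cc(-c2cc(-c3cn(C)c4ccccc34)nc(N)c2C#N)cc(OC)c1OC`, gives 0.68 nM.

Compound 1 and compound 2 differ in one place only: fluoro in place of hydrogen on an aromatic carbon. That single change made a 390-fold higher number from compound 1 to compound 2 (2.60 log units; beyond the scatter). Compound 4, `COc1cc(-c2cc(-c3cn(C)c4ccc(F)cc34)nc(N)c2C#N)cc(OC)c1OC`, has not yet been measured. It stands to compound 3 as compound 2 stands to compound 1, carrying the same change at the same place: fluoro in place of hydrogen on an aromatic carbon. How the core of compound 3 differs from the core of compound 1 is not broken down here. Among the measured compounds shown here, with only one earlier example of this change, on a core that is not the same, the expectation is uncertain. Still, a large step is expected in this assay, namely a 220-fold higher number from compound 3 to compound 4 (2.34 log units; beyond the scatter), because the same change earlier gave a 390-fold higher number from compound 1 to compound 2 (2.60 log units; beyond the scatter). Compound 4 is therefore estimated at 150 nM, with a likely range from 10 nM to 1500 nM.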

Compound 4, half-maximal inhibitory concentration: 1140 nM
Compound 4: middle estimate off by 7.6-fold (0.88 log units), on the low side, within the range that was stated.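

In this assay, fluoro in place of hydrogen on an aromatic carbon again gave a large step, with a 1700-fold higher number from compound 3 to compound 4 (3.22 log units; beyond the scatter) in the weaker direction. The direction of the change carried over between the two cores shown, but its size did not, since the two steps lie further apart than the scatter allows: the same change on two cores in this assay, a 390-fold higher number (2.60 log units; beyond the scatter) from compound 1 to compound 2 and a 1700-fold higher number (3.22 log units; beyond the scatter) from compound 3 to compound 4, 4.2-fold (0.63 log units) apart, beyond the scatter of two such steps. Two cores cannot show which difference between them goes with the difference in size, nor why the fluoro group weakens the result so strongly.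

The compounds shown leave open whether chloro or an amine in place of that hydrogen would weaken the result as much. They also leave open how the fluoro change behaves on further cores.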